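This account rests on a few compounds, and the source may have more. Where it says the series, first, only, none or still open, it means among the compounds named here.

Compound 1, `CC1CCN(C2CCN(S(=O)(=O)c3ccc(OCc4ccccc4)cc3)CC2)CC1`, gives > 5000 nM, a limit of the assay.
Compound 2, `CC1CCN(C2CCN(S(=O)(=O)c3nccn3C)CC2)CC1`, gives > 10000 nM, likewise a limit.

Both readings come from an ADME assay on HCT-116 cells (Homo sapiens) for cytotoxicity, read by CellTiter-Glo, with a stated time of 72 h; on this read-out lower numbers stand for stronger inhibition and higher numbers for weaker inhibition. Going by the values given here, compound 1 therefore stands only at a limit, with no number of its own, and the one further value shown is a limit too: the limit of > 5000 nM in this assay, at which 1 of the 2 values shown sits, and the limit of > 10000 nM in this assay, at which 1 of the 2 values shown sits, mark the two. Compound 3, `CC1CCN(C2CCN(S(=O)(=O)c3ccc(-c4ccccc4F)cc3)CC2)CC1`, differs from compound 1 by 2-fluorophenyl in place of benzyloxy on an aromatic carbon. Among the compounds with values here, no step between measured compounds is available, so in this assay no shift beyond the scatter is expected. Compound 3 is expected at 8000 nM, within 3000 nM to 30000 nM. The expected step is a step that the limit leaves unreadable from compound 1 to compound 3.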

Compound 3, half-maximal inhibitory concentration: > 5000 nM
Compound 3: a limit, no number; the forecaster's own chance of this, stated with the estimate: 75%; the middle value does not contradict the limit.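

Going by these compounds alone, compound 1 and compound 3 both stand at a limit in this assay, and no step between them can be read. The compounds shown leave open where any real inhibition begins: none has a number of its own.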